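Shortening the ester and toxicity to rabbit kidney cells

The source may report more compounds than this note shows. Statements on the series, on what has been measured and on what is new or still open speak of the compounds shown alone.

Three esters built on one shared core have been compared for their effect on cultured rabbit kidney cells. Compound 1, `CCCCCCCCOC(=O)C(O)Cn1cnc2c(N)ncnc21`, gives 100 ug/mL in a functional assay on PRK cells (Oryctolagus cuniculus) for cytotoxicity; on this read-out lower numbers stand for higher toxicity in this test and higher numbers for lower toxicity in this test. Compound 2, `CCCCOC(=O)C(O)Cn1cnc2c(N)ncnc21`, gives 200 ug/mL in this assay. Compound 3, `COCCOC(=O)C(O)Cn1cnc2c(N)ncnc21`, reaches only a limit of the method, > 400 ug/mL in this assay, and so its value is known only as the limit of > 400 ug/mL in this assay, at which 1 of the 3 values shown sits. The step of a 2.0-fold higher number from compound 1 to compound 2 (0.30 log units; within the scatter) stays within the scatter, whereas an at least 4.0-fold higher number from compound 1 to compound 3 (0.60 log units; beyond the scatter) moves beyond it, and an at least 2.0-fold higher number from compound 2 to compound 3 (0.30 log units; that floor lies within the scatter) has a floor that still lies within the scatter. The next member, compound 4, `COC(=O)C(O)Cn1cnc2c(N)ncnc21`, carries hydrogen in place of methoxymethyl on a saturated chain carbon bound to an oxygen next to a carbonyl group. No change at the ester so far has produced a lower number, but because compound 3 stands at the limit of > 400 ug/mL in this assay, at which 1 of the 3 values shown sits, no numeric step can be read from it, and the shortening from compound 3 to compound 4 is the smallest change in the set. The expected step of a number no higher from compound 3 to compound 4 (the limit leaves the size open) is therefore small, and another reading at the limit is the most probable outcome. Compound 4 is estimated at 400 ug/mL, within 200 ug/mL to 800 ug/mL, in this assay.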

Compound 4, minimum cytotoxic concentration: > 400 ug/mL
Compound 4: only a limit was reported (the forecaster's own chance of this, stated with the estimate: 70%); the middle value lies on the limit itself.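

With hydrogen in place of methoxymethyl on a saturated chain carbon bound to an oxygen next to a carbonyl group, compound 4 joins compound 3 at a limit of the method, so the two shortest esters can no longer be told apart in this assay: the limit of > 400 ug/mL in this assay, at which 2 of the 4 values shown sit.

Any step between these two limits cannot be read, but the methyl ester still gives an at least 4.0-fold higher number from compound 1 to compound 4 (0.60 log units; beyond the scatter), while an at least 2.0-fold higher number from compound 2 to compound 4 (0.30 log units; that floor lies within the scatter) leaves only a floor that is no firm separation. What is new is that the limit is reached both with 2-methoxyethyl and with methyl, so the ether oxygen of compound 3 is not required for a reading at the limit.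

From the compounds shown here alone, how far the true values of compound 3 and compound 4 lie past the limit remains open, so any difference between these two esters stays hidden. For the compounds shown here, also open is how the read-out would respond to a carboxylic acid in place of the ester, to an amine on the ester chain, or to a chain longer than the one in compound 1.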